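The source may hold more compounds than are shown below. What is called first, only, known or untested is meant among the compounds shown, and "the series" means these compounds.

Working notes on the series. Compound 2 `CC1CC(C(=O)Nc2nc3ccc(OC(F)(F)F)cc3s2)CC(C)(C)C1` carries a trifluoromethoxy group on the shared core. In an ADME assay on isolated protein for inhibition of cytochrome P450 2B6 (Homo sapiens) (a lower number here means a stronger inhibitor, a higher number a weaker inhibitor), compound 2 reaches only the limit of the assay, > 20000 nM, so no number stands for it. The measured reference is compound 1 `CC1CC(C(=O)Nc2nc3ccc(Br)cc3s2)CC(C)(C)C1`, which in this assay gives 12800 nM. The step between them, an at least 1.5-fold higher number from compound 1 to compound 2 (0.19 log units; that floor lies within the scatter), is known only as a floor because the limit of > 20000 nM in this assay, at which 1 of the 2 values shown sits, is where compound 2 sits.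

Compound 3 `CC1CC(C(=O)Nc2nc3ccc(Cl)cc3s2)CC(C)(C)C1` differs from compound 2 by chloro in place of trifluoromethoxy on an aromatic carbon. For the measured compounds named here, the one step that bears on this change is an at least 1.5-fold higher number from compound 1 to compound 2 (0.19 log units; that floor lies within the scatter), which runs the other way, from bromo to trifluoromethoxy, and whose true size is open. Chloro and bromo are each a single halogen atom on the same aromatic carbon, so compound 1 is the nearer reference. Compound 3 is therefore expected at 13000 nM, with a range from 6000 nM to 30000 nM. The step this estimate implies is expected to be an at least 1.5-fold lower number from compound 2 to compound 3 (0.18 log units; that floor lies within the scatter), toward a lower number, though its floor-bounded starting point leaves it uncertain whether it clears the scatter.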

Compound 3, half-maximal inhibitory concentration: 14900 nM
Estimate against measurement, compound 3: 1.1-fold (0.06 log units) below, within the range that was stated.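

In this assay, chloro and bromo on this aromatic carbon cannot be told apart: a 1.2-fold higher number from compound 1 to compound 3 (0.07 log units; within the scatter), so compound 1 and compound 3 stand together as the two single-halogen members of the series, and exchanging one halogen for the other at this place leaves the number within the scatter. Seen from the other side, chloro in place of trifluoromethoxy gives an at least 1.3-fold lower number from compound 2 to compound 3 (0.12 log units; that floor lies within the scatter), which adds a second comparison for the trifluoromethoxy group but does not separate it from chloro beyond the scatter. That step is only a floor, and its true size is open, because compound 2 stands at a limit of the assay and not at a number: the limit of > 20000 nM in this assay, at which 1 of the 3 values shown sits.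

The compounds shown leave open whether trifluoromethoxy differs from either single halogen by more than the scatter at this place. They also do not tell how a fluoro group, an amine, a carboxylic acid or a longer chain on this aromatic carbon would read in this assay, or whether any such group would move the number clearly away from that of compound 1.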